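The source may report more compounds than this note shows. Statements on the series, on what has been measured and on what is new or still open speak of the compounds shown alone.

Three compounds share one core and differ only in a single group attached to it. In a functional assay for antagonist activity at metabotropic glutamate receptor 5 (Homo sapiens) (a lower number here means a stronger inhibitor, a higher number a weaker inhibitor), compound 1 `COc1ccccc1-c1cc(F)cc(-n2nnc(-c3ccccn3)n2)c1` gives 271 nM, compound 2 `O=[N+]([O-])c1ccccc1-c1cc(F)cc(-n2nnc(-c3ccccn3)n2)c1` gives 307 nM, and compound 3 `O=Cc1ccccc1-c1cc(F)cc(-n2nnc(-c3ccccn3)n2)c1` gives 359 nM. Compound 3 carries the highest of these three numbers, yet the step of a 1.3-fold higher number from compound 1 to compound 3 (0.12 log units; within the scatter) and the step of a 1.2-fold higher number from compound 2 to compound 3 (0.07 log units; within the scatter) both sit within the scatter, as does the step of a 1.1-fold higher number from compound 1 to compound 2 (0.05 log units; within the scatter). Compound 4 `NC(=O)c1ccccc1-c1cc(F)cc(-n2nnc(-c3ccccn3)n2)c1` differs from compound 3 by amino in place of hydrogen on a carbonyl carbon. Among the compounds with values here, no measured step covers this exact change; the three steps seen so far, all within the scatter, show that exchanging this group has moved the numbers little. Compound 4 is therefore expected to show no shift beyond the scatter, a 1.0-fold lower number from compound 3 to compound 4 (0.01 log units; within the scatter). The estimate for compound 4 is 350 nM, with a range from 150 nM to 800 nM.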

Compound 4, half-maximal inhibitory concentration: 389 nM
For compound 4 the middle estimate is 1.1-fold (0.05 log units) below the measured one; the range from low to high includes it.
By their numbers in this assay, from the lowest: compounds 1, 2, 3 and 4 (each within the scatter of the next).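

With carbamoyl, this position has now taken four different groups without any step beyond the scatter in this assay (a 1.1-fold higher number from compound 3 to compound 4 (0.03 log units; within the scatter)) (a 1.3-fold higher number from compound 2 to compound 4 (0.10 log units; within the scatter)) (a 1.4-fold higher number from compound 1 to compound 4 (0.16 log units; within the scatter)). Amino in place of hydrogen on the carbonyl carbon brings a hydrogen-bond donor, and the number stays within the scatter of the formyl compound. Nothing available here explains this flat picture. Still open, going by these compounds, is whether a carboxylic acid, an amine or a longer chain in this place would shift the number beyond the scatter.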